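Shifting the chlorine on the urea aryl ring

The source may report more compounds than this note shows. Statements on the series, on what has been measured and on what is new or still open speak of the compounds shown alone.

The measured compounds:
Compound 1, `CN(C)CCCNc1nc(-c2ccc(NC(=O)Nc3ccccc3Cl)cc2)nc2ccsc12`, gives 430 nM in a functional assay on NCI-H460 cells (Homo sapiens) for cytotoxicity, read by MTT assay, with a stated time of 72 h; a higher number here means a weaker inhibitor, a lower number a stronger inhibitor.
Compound 2, `CN(C)CCNc1nc(-c2ccc(NC(=O)Nc3ccccc3Cl)cc2)nc2ccsc12`, gives 230 nM in this assay.
Compound 3, `CCN(CC)CCCNc1nc(-c2ccc(NC(=O)Nc3ccc(Cl)cc3)cc2)nc2ccsc12`, gives 81 nM in this assay.

Compound 3 stands lowest of the three numbers in this assay. Its nearest neighbour is compound 2, whose number is higher by a gap beyond the scatter, and compound 1 lies furthest away. Within the data shown here, the only single-point step among the measured compounds is a 1.9-fold lower number from compound 1 to compound 2 (0.27 log units; within the scatter), and that concerns the amine chain rather than the aryl ring of the urea.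

Compound 4, `CCN(CC)CCCNc1nc(-c2ccc(NC(=O)Nc3ccccc3Cl)cc2)nc2ccsc12`, differs from compound 3 by 2-chlorophenyl in place of 4-chlorophenyl on an amide-type nitrogen. Among the measured compounds shown here, no measured pair differs in this way alone: compounds 2 and 3 differ both in the placement of the chlorine and in the amine chain, so their gap cannot be split between the two changes. Compound 4 shares the 2-chlorophenyl group with compounds 1 and 2 and the diethylaminopropyl chain with compound 3, so the expectation is a number somewhere between those of compound 3 and compound 2. The estimate for compound 4 in this assay is 150 nM, expected to lie between 60 nM and 400 nM, a step of a 1.9-fold higher number from compound 3 to compound 4 (0.27 log units; within the scatter).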

Compound 4, half-maximal inhibitory concentration: 200 nM
Estimate against measurement, compound 4: 1.3-fold (0.12 log units) below, and the stated range covers the measured number.
By their numbers in this assay, from the lowest: compound 3; then compounds 4, 2 and 1 (each within the scatter of the next, the first and the last beyond it).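

In this assay, among these compounds, the change of position alone now has a reading: with the diethylaminopropyl chain held fixed, 2-chlorophenyl in place of 4-chlorophenyl on the amide-type nitrogen gives a 2.5-fold higher number from compound 3 to compound 4 (0.39 log units; beyond the scatter), a modest step that the earlier compounds could not separate from the change in the amine chain. Among the compounds shown here, the new compound also gives the first readings of the amine with the 2-chlorophenyl group held fixed: diethylamino in place of dimethylamino on the propyl chain gives a 2.2-fold lower number from compound 1 to compound 4 (0.33 log units; beyond the scatter), also modest, whereas the change from the shorter dimethylaminoethyl chain of compound 2 gives a 1.2-fold lower number from compound 2 to compound 4 (0.06 log units; within the scatter), which does not separate the two compounds. No measurement among these data bears on what lies behind the difference between the two chlorine placements.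

The compounds shown leave open how 3-chlorophenyl, 4-fluorophenyl or unsubstituted phenyl would read on the same nitrogen, and whether the step between the two chlorine placements recurs with a dimethylamino chain. They also leave open how a cyclic amine such as morpholine or piperidine would read in place of diethylamino at the end of the chain.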